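Adding a Methoxy Group: Expected Growth Inhibition for Compound 4

The source may report more compounds than this note shows. Statements on the series, on what has been measured and on what is new or still open speak of the compounds shown alone.

Compound 1 `COc1ccc(C2=NN(C3=NC(=O)/C(=C4\C(=O)Nc5ccccc54)S3)C(c3ccc(OC)cc3)C2)cc1`: 100000 nM
Compound 2 `O=C1N=C(N2N=C(c3ccccc3)CC2c2ccc(Cl)cc2)S/C1=C1/C(=O)Nc2ccccc21`: 850 nM
Compound 3 `Cc1ccc2c(c1)/C(=C1\SC(N3N=C(c4ccccc4)CC3c3ccc(Cl)cc3)=NC1=O)C(=O)N2`: 520 nM

Of the compounds shown here, three sharing one core have been measured in a functional assay on cells (Cancer cell lines, Homo sapiens) for cytotoxicity, read by sulforhodamine B assay, with a stated time of 48 h; on this read-out higher numbers stand for weaker inhibition of growth and lower numbers for stronger inhibition of growth. Compound 2 gives the second highest of the three numbers. Its nearest neighbour is compound 3, reached by a 1.6-fold lower number from compound 2 to compound 3 (0.21 log units; within the scatter), a change too small to count as real. Within the data shown here, the furthest is compound 1, whose number lies far above that of compound 2, but these two differ in two places at once, so no single-point step links them.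

Compound 4 `COc1ccc(C2=NN(C3=NC(=O)/C(=C4\C(=O)Nc5ccccc54)S3)C(c3ccc(Cl)cc3)C2)cc1` is the unmeasured compound. Relative to compound 2 the change is methoxy in place of hydrogen on an aromatic carbon. Among the measured compounds shown here, the only single-point step in hand, from compound 2 to compound 3, stayed within the scatter, and it concerns a different group on a different ring, so it bears only loosely on this change. The two compounds carrying a methoxy at this position, compound 1 and compound 4, are otherwise not directly comparable with compound 2. The estimate for compound 4 is therefore a modest weakening, a step of a 2.9-fold higher number from compound 2 to compound 4 (0.47 log units; beyond the scatter), with wide uncertainty. Compound 4 is expected to give about 2500 nM in this assay, likely between 500 nM and 20000 nM.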

Compound 4, concentration for total growth inhibition: 100000 nM
For compound 4 the middle estimate is 40-fold (1.60 log units) below the measured one, and the stated range ends below it.
By their numbers in this assay, from the lowest: compounds 3 and 2 (each within the scatter of the next); then compounds 1 and 4 (each within the scatter of the next).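

Putting methoxy on this aromatic carbon, turning phenyl into 4-methoxyphenyl, gives a 120-fold higher number from compound 2 to compound 4 (2.07 log units; beyond the scatter), so this position is far less tolerant than the earlier methyl step on the other side of the molecule, a 1.6-fold lower number from compound 2 to compound 3 (0.21 log units; within the scatter), could suggest. Chloro in place of methoxy on the second aromatic ring then gives no change at the digits printed from compound 1 to compound 4 (within the scatter), so with the methoxy of compound 4 in place, that swap leaves the growth inhibition unchanged, and the wide gap between compound 1 and compound 2 is matched by the single methoxy step alone. Nothing available here explains why this methoxy weakens growth inhibition so strongly.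

As far as these compounds go, only hydrogen and methoxy appear at this position, so it remains open whether a smaller group such as fluoro or hydroxyl would be tolerated. An amine or a longer chain such as ethoxy at the same place is equally untested in the compounds shown.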